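Working notes: extending the vinyl group of compound 3

The source may report more compounds than this note shows. Statements on the series, on what has been measured and on what is new or still open speak of the compounds shown alone.

Values in a functional assay on A549 cells (Homo sapiens) for antiproliferative activity, read by MTT assay, with a stated time of 72 h; on this read-out higher numbers stand for weaker inhibition and lower numbers for stronger inhibition:
- Compound 1 `C=CC(=O)Nc1cccc(Oc2nc(Nc3ccn(C)n3)nc3c2CSCC3)c1`: 18600 nM
- Compound 2 `C=C(F)C(=O)Nc1cccc(Oc2nc(Nc3ccn(C)n3)nc3c2CSCC3)c1`: > 50000 nM (a limit)
- Compound 3 `C=CC(=O)Nc1cccc(Oc2nc(Nc3cccc(OC)c3)nc3c2CSCC3)c1`: 10100 nM

For the measured compounds named here, the gap between the only two true numbers is small: a 1.8-fold lower number from compound 1 to compound 3 (0.27 log units; within the scatter). Compound 3 therefore stands level with compound 1, and the third value is a limit.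

In compound 4 `COc1cccc(Nc2nc3c(c(Oc4cccc(NC(=O)/C=C/C(C)C)c4)n2)CSCC3)c1`, the change from compound 3 is 3-methylbut-1-en-1-yl in place of vinyl on a carbonyl carbon.

The closest measured change on this chain is an at least 2.6-fold higher number from compound 1 to compound 2 (0.42 log units; beyond the scatter). The other step concerns a group on a nitrogen and does not bear on this change. A modest rise is therefore expected in this assay, though one precedent is thin support.

The expected change is a 2.6-fold higher number from compound 3 to compound 4 (0.41 log units; beyond the scatter).

Compound 4 is estimated at 26000 nM, with an expected range of 11000 nM to 50000 nM.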

Compound 4, half-maximal inhibitory concentration: 25300 nM
Beside the measured number, compound 4's estimate is 1.0-fold (0.01 log units) above it, and the stated range covers the measured number.
By their numbers in this assay, from the lowest: compounds 3, 1 and 4 (each within the scatter of the next, the first and the last beyond it). At a limit, above all of these: compound 2.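

In this assay, 3-methylbut-1-en-1-yl in place of vinyl on the carbonyl carbon gives a 2.5-fold higher number from compound 3 to compound 4 (0.40 log units; beyond the scatter). This is the only exact size for a change on this chain, as the fluoro change in compound 2 ends at a limit, and it is read with 3-methoxyphenyl on the nitrogen rather than 1-methyl-1H-pyrazol-3-yl. Nothing measured here accounts for the rise. Open, on these data alone, is whether a chain ending in a dimethylamine would read the same, and whether this change carries over to the 1-methyl-1H-pyrazol-3-yl compounds.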